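Chloro to Trifluoromethyl, Compound 3 to Compound 4

This account rests on a few compounds, and the source may have more. Where it says the series, first, only, none or still open, it means among the compounds named here.

Compound 3 `FC(F)(F)c1ccc(CSc2nc(Nc3ccc(Cl)cc3)c3ccccc3n2)cc1` gives the lower of the two numbers in a functional assay on MDA-MB-231 cells (Homo sapiens) for cytotoxicity, read by MTT assay, with a stated time of 72 h (on this read-out lower numbers stand for stronger inhibition and higher numbers for weaker inhibition), with 15100 nM. Compound 1 `CCCCCCNc1nc(SCc2ccc(C(F)(F)F)cc2)nc2ccccc12` gives 20200 nM in this assay, and the step of a 1.3-fold lower number from compound 1 to compound 3 (0.13 log units; within the scatter) is within the scatter. For compound 2 `FC(F)(F)c1ccc(CSc2nc(Nc3ccccc3C(F)(F)F)c3ccccc3n2)cc1` this assay reports only a limit, > 50000 nM (the limit of > 50000 nM in this assay, at which 1 of the 3 values shown sits). The steps of an at least 2.4-fold higher number from compound 1 to compound 2 (0.39 log units; beyond the scatter) and an at least 3.3-fold lower number from compound 2 to compound 3 (0.51 log units; beyond the scatter) exchange the whole group on the nitrogen and so do not isolate the single substituent.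

Compound 4 `FC(F)(F)c1ccc(CSc2nc(Nc3ccc(C(F)(F)F)cc3)c3ccccc3n2)cc1` differs from compound 3 by trifluoromethyl in place of chloro on an aromatic carbon. Among the compounds with values here, no measured step alters only this aromatic carbon, so the expectation rests on compound 3 alone. The expected step is a 1.2-fold higher number from compound 3 to compound 4 (0.08 log units; within the scatter), no more than the scatter. Compound 4 is estimated at 18000 nM, range 7000 nM to 50000 nM.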

Compound 4, half-maximal inhibitory concentration: 5460 nM
Estimate against measurement, compound 4: 3.3-fold (0.52 log units) above; measured number below the stated range.
By their numbers in this assay, from the lowest: compound 4; then compounds 3 and 1 (each within the scatter of the next). At a limit, above all of these: compound 2.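

In this assay, within the data shown here, the group on this aromatic carbon matters: a 2.8-fold lower number from compound 3 to compound 4 (0.44 log units; beyond the scatter), the only step here that changes a single substituent on the ring. The 4-(trifluoromethyl)phenyl group also separates from hexyl, with a 3.7-fold lower number from compound 1 to compound 4 (0.57 log units; beyond the scatter), which the 4-chlorophenyl group did not do. The 4-(trifluoromethyl)phenyl group in place of 2-(trifluoromethyl)phenyl gives an at least 9.1-fold lower number from compound 2 to compound 4 (0.96 log units; beyond the scatter), which is only a bound, as the value of compound 2 is a limit of the assay: the limit of > 50000 nM in this assay, at which 1 of the 4 values shown sits.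

Chloro and trifluoromethyl are only two points at this carbon and set no trend. As far as these compounds go, whether a nitrile, a methoxy group or an amine there would follow the same direction stays open.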